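Swapping an Ester Tail on a Glycoside Core

The compounds below may be only part of what the source reports. "The series", "measured", "known", "first", "only" and "open" are said of these compounds alone.

Compound 1 `C/C=C1/[C@H](O[C@@H]2O[C@H](COC(C)=O)[C@@H](OC(C)=O)[C@H](OC(C)=O)[C@H]2OC(C)=O)OC=C(C(=O)OC)[C@H]1CC(=O)OCCCCCCCCCCCCCCC`: 3810 nM
Compound 2 `C/C=C1/[C@H](O[C@@H]2O[C@H](CO)[C@@H](O)[C@H](O)[C@H]2O)OC=C(C(=O)OC)[C@H]1CC(=O)OCc1ccc2c(c1)OCCO2`: > 15000 nM (a limit)
Compound 3 `C#CCOC(=O)C[C@@H]1C(C(=O)OC)=CO[C@@H](O[C@@H]2O[C@H](COC(C)=O)[C@@H](OC(C)=O)[C@H](OC(C)=O)[C@H]2OC(C)=O)/C1=C/C`: > 15000 nM (a limit)

In a functional assay on SK-BR-3 cells (Homo sapiens) for antiproliferative activity, read by MTT assay, with a stated time of 72 h (on this read-out lower numbers stand for stronger inhibition and higher numbers for weaker inhibition), compound 1 gives 3810 nM. Compound 2, whose sugar carries free hydroxyl groups, reaches only a limit of the assay in this assay, > 15000 nM. Compound 3 likewise gives only a limit in this assay, > 15000 nM. So compound 2 stands among the weaker entries here, with no number of its own; the picture is summed up by the limit of > 15000 nM in this assay, at which 2 of the 3 values shown sit.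

Compound 4 `C/C=C1/[C@H](O[C@@H]2O[C@H](CO)[C@@H](O)[C@H](O)[C@H]2O)OC=C(C(=O)OC)[C@H]1CC(=O)OCCc1ccc(OC)cc1` keeps the free sugar and the shared core of compound 2 and changes only the ester tail: 4-methoxybenzyl in place of 2,3-dihydro-1,4-benzodioxin-6-yl on a saturated chain carbon bound to an oxygen next to a carbonyl group. Going by the values given here, no measured pair shows a change of this kind, so there is nothing to scale a step against. Because compound 2 sits at the limit of > 15000 nM in this assay, at which 2 of the 3 values shown sit, the expectation is that compound 4 also remains at or near the limit, with a step that the limit leaves unreadable from compound 2 to compound 4 that is not expected to exceed the scatter. Compound 4 is therefore estimated at 20000 nM, in a range from 8000 nM to 60000 nM.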

Compound 4, half-maximal inhibitory concentration: > 20000 nM
Compound 4: only a limit was reported; the forecaster's own chance of this, stated with the estimate: 70%; the middle value lies on the limit itself.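

Going by these compounds alone, compound 2 and compound 4 both give only a limit of the assay in this assay, so no step between them can be read. The compounds shown leave open whether 4-methoxybenzyl in place of 2,3-dihydro-1,4-benzodioxin-6-yl changes the activity at all, and by how much.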